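One Inverted Stereocentre, Three Compounds at the Limit

The source may report more compounds than this note shows. Statements on the series, on what has been measured and on what is new or still open speak of the compounds shown alone.

Compound 2 `C=C1C[C@@H](O)[C@@H](Br)C(C)(C)[C@@]12C=C[C@](O)(C(Br)Br)CC2` is the starting point. In a functional assay on A549 cells (Homo sapiens) for cytotoxicity, read by resazurin assay (a lower number here means a stronger inhibitor, a higher number a weaker inhibitor), compound 2 gives >= 10000 nM, which is a limit of the assay rather than a measured number. Compound 1 `CC1(C)[C@H](Br)[C@H](O)C[C@@]2(CO2)[C@@]12CCC(=O)[C@@H]1O[C@@H]12` likewise gives only the limit >= 10000 nM in this assay. Compound 3 `C=C1C[C@@H](O)[C@@H](Br)C(C)(C)[C@@]12C=C[C@](O)(CO)CC2` also gives the limit >= 10000 nM in this assay. Thus (the limit of >= 10000 nM in this assay, at which 3 of the 3 values shown sit), and the single one-place step between measured compounds, a step that the two limits leave unreadable from compound 2 to compound 3, cannot be sized. Compound 4 `C=C1C[C@@H](O)[C@@H](Br)C(C)(C)[C@@]12C=C[C@@](O)(C(Br)Br)CC2` is the unmeasured neighbour of compound 2: the two compounds have the same atoms and bonds and differ only in configuration as drawn: 1 of 4 stereo elements differ; a stereocentre at a saturated ring carbon is drawn S in compound 2 and R in compound 4. For the measured compounds named here, no measured step involves a change of configuration alone, and the one measured step is unreadable, so no shift beyond the scatter in either direction can be expected. Compound 4 is therefore estimated at 10000 nM, with a range of 4000 nM to 30000 nM, an expected step of a number no higher from compound 2 to compound 4 (the limit leaves the size open).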

Compound 4, half-maximal inhibitory concentration: >= 10000 nM
Compound 4: a limit, no number; the forecaster's own chance of this, stated with the estimate: 80%; the middle value lies on the limit itself.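

No step can be read between compound 2 and compound 4, since both values are limits of the assay, not numbers: the limit of >= 10000 nM in this assay, at which 4 of the 4 values shown sit.

The compounds shown leave open whether the configuration at that stereocentre, or any other change among them, alters activity at all.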